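Amide nitrogen substituent: oxetan-3-yl to 1-methyl-1H-imidazol-2-yl

The compounds below may be only part of what the source reports. "The series", "measured", "known", "first", "only" and "open" are said of these compounds alone.

Measured compounds in an assay on HEK293 cells for agonist activity at transient receptor potential cation channel subfamily M member 8 (Homo sapiens), read by fluorescence and calcium flux, with a stated time of 15 min; a lower number here means that less compound is needed, a higher number that more compound is needed for the effect:
compound 1 `Cc1ccc(OCC(=O)N(Cc2cccs2)c2cccnc2)cc1` gives 198 nM
compound 2 `CON(Cc1cccs1)C(=O)COc1ccc(C)cc1` gives 10 nM
compound 3 `Cc1ccc(OCC(=O)N(Cc2cccs2)C2COC2)cc1` gives 23000 nM

Compound 3 stands highest of the three numbers in this assay. The step from compound 1 to it is a 120-fold higher number from compound 1 to compound 3 (2.07 log units; beyond the scatter), and from compound 2 it is a 2300-fold higher number from compound 2 to compound 3 (3.36 log units; beyond the scatter); both steps place oxetan-3-yl on the amide-type nitrogen, and both raise the number by a large margin.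

Compound 4 `Cc1ccc(OCC(=O)N(Cc2cccs2)c2nccn2C)cc1` removes that group again: 1-methyl-1H-imidazol-2-yl in place of oxetan-3-yl on an amide-type nitrogen. Among the compounds with values here, no measured step covers the entering group itself. The closest comparison is compound 1, where an aromatic ring, pyridin-3-yl, sits on the same nitrogen and gives 198 nM in this assay. Since the step to compound 3 from compound 1 raised the number strongly, the reverse direction, back to an aromatic ring, is expected to lower it by a large step, a 58-fold lower number from compound 3 to compound 4 (1.76 log units; beyond the scatter). Whether 1-methyl-1H-imidazol-2-yl behaves like pyridin-3-yl is not known from these data, and the gap between compound 1 and compound 2 shows that the substituent on this nitrogen moves the number widely. Compound 4 is therefore estimated in this assay at 400 nM, with a range of 60 nM to 3000 nM.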

Compound 4, half-maximal effective concentration: 1790 nM
Compound 4: middle estimate off by 4.5-fold (0.65 log units), on the low side; the measured number falls inside the stated range.
By their numbers in this assay, from the lowest: compound 2; then compound 1; then compound 4; then compound 3.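

In this assay, 1-methyl-1H-imidazol-2-yl on the amide-type nitrogen recovers only part of the ground lost with oxetan-3-yl, with a 13-fold lower number from compound 3 to compound 4 (1.11 log units; beyond the scatter), and it does not match pyridin-3-yl, with a 9.0-fold higher number from compound 1 to compound 4 (0.96 log units; beyond the scatter). An aromatic ring at this place is therefore no guarantee of a given number: the two aromatic rings shown differ beyond the scatter, and the gap to methoxy remains large, with a 180-fold higher number from compound 2 to compound 4 (2.25 log units; beyond the scatter). No measurement at hand explains these differences.

Going by these compounds, it remains open whether the low number of compound 2 is particular to methoxy or would extend to an ethoxy or hydroxy group on this nitrogen. Also open, on these data alone, is where a plain phenyl ring or a simple methyl group would fall relative to pyridin-3-yl and 1-methyl-1H-imidazol-2-yl.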